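The source may hold more compounds than are shown below. What is called first, only, known or untested is meant among the compounds shown, and "the series" means these compounds.

Compound 1 `CCCc1ccc(NC(=O)C2CCN(C/C=C/c3ccccc3)CC2)cc1` gives the lower of the two numbers measured in a functional assay on A549 cells (Homo sapiens) for inhibition, read by MTT assay, with a stated time of 72 h (on this read-out lower numbers stand for stronger inhibition and higher numbers for weaker inhibition), at 9470 nM. Compound 2 `O=C(Nc1cccc2cccnc12)C1CCN(C/C=C/c2ccccc2)CC1` gives 51600 nM in this assay, and its gap from compound 1 lies outside the usual scatter. Compound 3 `O=C(Nc1ccccn1)C1CCN(C/C=C/c2ccccc2)CC1` differs from compound 1 in one place: pyridin-2-yl in place of 4-propylphenyl on an amide-type nitrogen. Among the measured compounds shown here, no measured pair shows this exact change, so the expectation rests on the two values alone, and a weakening beyond the scatter is expected, a 3.2-fold higher number from compound 1 to compound 3 (0.50 log units; beyond the scatter). Compound 3 is accordingly estimated at 30000 nM, within a range from 8000 nM to 100000 nM.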

Compound 3, half-maximal inhibitory concentration: 89300 nM
The estimate for compound 3 lay 3.0-fold (0.47 log units) below the measured number; measured number inside the range.
By their numbers in this assay, from the lowest: compound 1; then compounds 2 and 3 (each within the scatter of the next).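

At the amide-type nitrogen, pyridin-2-yl in place of 4-propylphenyl gives the first step read at this position: in this assay, the change brings a 9.4-fold higher number from compound 1 to compound 3 (0.97 log units; beyond the scatter). In this one pair, the group with a ring nitrogen and fewer heavy atoms goes with weaker inhibition. Nothing at hand accounts for this step. From the compounds shown here alone, whether the step follows the loss of the propyl chain or the arrival of the ring nitrogen stays open. A plain phenyl or a 4-methylphenyl on the same nitrogen would help separate the two.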